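This account rests on a few compounds, and the source may have more. Where it says the series, first, only, none or still open, it means among the compounds named here.

Compound 1 `CCN1CCN(C(=S)SCC(=O)N(Cc2ccc(OC)cc2)c2cc(OC)c(OC)c(OC)c2)CC1`: 3070 nM
Compound 2 `COc1ccc(CN(C(=O)CSC(=S)N2CCN(C(=O)OC(C)(C)C)CC2)c2cc(OC)c(OC)c(OC)c2)cc1`: 250 nM
Compound 3 `COc1ccc(CN(C(=O)CSC(=S)N2CCN(C(=O)OC(C)(C)C)CC2)c2ccc(C)cc2)cc1`: > 20000 nM, a limit of the assay

In a functional assay on KYSE-450 cells (Homo sapiens) for inhibition, read by CCK-8 assay, with a stated time of 48 h (a lower number here means a stronger inhibitor, a higher number a weaker inhibitor), compound 2 gives 250 nM, the lowest of the values shown. Compound 4 `COc1ccc(CN(C(=O)CSC(=S)N2CCN(C(=O)OC(C)(C)C)CC2)c2cc(OC)c(OC)c(OC)c2)cc1OC` carries 3,4-dimethoxybenzyl in place of the 4-methoxybenzyl of compound 2: methoxy in place of hydrogen on an aromatic carbon. For the measured compounds named here, two measured steps bear on this only indirectly, since neither touches the benzyl group. Both are large: a 12-fold lower number from compound 1 to compound 2 (1.09 log units; beyond the scatter) at the amine nitrogen in the ring, and an at least 80-fold higher number from compound 2 to compound 3 (1.90 log units; beyond the scatter) on the amide-type nitrogen. They give no direct size for an added methoxy here. A modest rise in the number is expected, a 1.6-fold higher number from compound 2 to compound 4 (0.20 log units; within the scatter), possibly within the scatter. For compound 4 the estimate is 400 nM, with an expected range of 120 nM to 1500 nM.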

Compound 4, half-maximal inhibitory concentration: > 20000 nM
Compound 4: no number, only a limit; the forecaster's own chance of this, stated with the estimate: 5%; at least 50-fold (1.69 log units) between middle value and limit.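

For the compounds shown here, on the benzyl group, which no earlier step touched, methoxy in place of hydrogen ortho to a methoxy group gives, in this assay, an at least 80-fold higher number from compound 2 to compound 4 (1.90 log units; beyond the scatter). A single small addition at this position therefore has a large effect, so activity in this series depends on the benzyl group as well as on the two places already probed. The upper end of this step is a limit, not a number: the limit of > 20000 nM in this assay, at which 2 of the 4 values shown sit.

As far as these compounds go, it remains open whether a smaller or different group on that aromatic carbon, such as fluoro, hydroxy or methyl, keeps the activity of compound 2. A benzyl group with no methoxy at all also remains untested among the compounds shown here.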